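Benzimidazole anilides: shortening the chain in compound 4

The compounds below may be only part of what the source reports. "The series", "measured", "known", "first", "only" and "open" are said of these compounds alone.

Compound 1, `O=C(CCc1ccccc1)Nc1cccc(-c2nc3ccc(Br)cc3[nH]2)c1`: 14500 nM
Compound 2, `O=S(=O)(Nc1cccc(-c2nc3ccccc3[nH]2)c1)c1ccccc1`: 36000 nM
Compound 3, `O=C(CCCc1ccccc1)Nc1ccc(-c2nc3ccc(Br)cc3[nH]2)cc1`: 58000 nM

The three measured compounds were run in an assay on cells for inhibition of matrix metalloproteinase-9 (Homo sapiens), read by fluorescence, with stated times of 15 min and 4 h; a higher number here means a weaker inhibitor, a lower number a stronger inhibitor. Compound 3 gives the highest of the three numbers there. Its nearest neighbour is compound 2, whose number lies within the usual scatter of that of compound 3, so no order between these two can be read. Compound 1 sits furthest away, with a number that is lower than that of compound 3 by more than the scatter; compound 1 also carries its amide at a different position of the aniline and bears the same chain that compound 4 will have, so the two differences cannot be separated.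

Compound 4, `O=C(CCc1ccccc1)Nc1ccc(-c2nc3ccc(Br)cc3[nH]2)cc1`, is not yet measured. It differs from compound 3 in one place: phenyl in place of benzyl on a saturated chain carbon, two bonds along the chain from a carbonyl carbon, the same difference, cut one bond further out, reading phenethyl to benzyl. Among the measured compounds shown here, no measured pair shows this step on its own. Given that compound 1 gives 14500 nM with this chain, a modest move toward a lower number is expected, though it may fall within the scatter; the step is estimated as a 1.9-fold lower number from compound 3 to compound 4 (0.29 log units; within the scatter). For compound 4 the estimate in this assay is 30000 nM, with a range from 10000 nM to 90000 nM.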

Compound 4, half-maximal inhibitory concentration: 11500 nM
For compound 4 the middle estimate is 2.6-fold (0.42 log units) above the measured one; the range from low to high includes it.
By their numbers in this assay, from the lowest: compounds 4 and 1 (each within the scatter of the next); then compounds 2 and 3 (each within the scatter of the next).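

In this assay, among the compounds shown here, shortening the chain on the carbonyl from 3-phenylpropyl to phenethyl gives a 5.0-fold lower number from compound 3 to compound 4 (0.70 log units; beyond the scatter), the first step that isolates chain length at this position. With the phenethyl chain in both, compound 4 at 11500 nM and compound 1 at 14500 nM lie within the scatter of each other, so the different amide placement on the aniline gives no readable difference for this chain. Nothing measured here accounts for the step.

On these data alone, it remains open whether a still shorter benzyl chain would keep the lower number, or whether a carboxylic acid or an amine at the chain end would be tolerated. The contribution of the bromine also stays unresolved, as compound 2 lacks it but differs in other places too.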